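Series notes: nitro in place of hydroxy, Vero cytotoxicity

A few compounds are considered here, and "the series" means these few. Any claim that something is new, unique, unknown or untested is made for them only; others in the source may bear on it.

Compound 2 `C=CCN(CC=C)C(=S)N/N=C\c1ccccc1O` gives "not determined" (no result reported) in an ADME assay on Vero cells (Chlorocebus sabaeus) for cytotoxicity, read by MTT assay, with a stated time of 72 h (a lower number here means that less compound is tolerated, a higher number that more compound is tolerated), meaning no result was obtained for it. Going by the values given here, the two measured members give the only bearings: compound 1 `C=CCN(CC=C)C(=S)N/N=C\c1ccc(Cl)cc1` gives 213000 nM in this assay, and compound 3 `C/C(=N/NC(=S)N(Cc1ccccc1)Cc1ccccc1)c1ccccc1O` gives 160000 nM in this assay. Compound 4 `C=CCN(CC=C)C(=S)N/N=C\c1ccccc1[N+](=O)[O-]` carries the change nitro in place of hydroxy on an aromatic carbon relative to compound 2. Among the compounds with values here, no step between measured compounds covers this change, so nothing measured supports a shift in this assay beyond the scatter in either direction, and none is expected. Compound 4 is expected to sit in the same weakly cytotoxic region as the measured members, at an estimated 180000 nM with a range from 60000 nM to 450000 nM.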

Compound 4, half-maximal cytotoxic concentration: 205000 nM
Compound 4: the middle estimate sits 1.1-fold (0.06 log units) below what was measured, within the range that was stated.
By their numbers in this assay, from the lowest: compounds 3, 4 and 1 (each within the scatter of the next).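

Going by these compounds alone, compound 4 yields no new step: compound 2 has no number in this assay and compound 1 and compound 3 differ from compound 4 in more than one place. The compounds shown leave open what nitro in place of hydroxy does in this assay and offer no evidence on any cause.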